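Series notes: from compound 2 to compound 4

A few compounds are considered here, and "the series" means these few. Any claim that something is new, unique, unknown or untested is made for them only; others in the source may bear on it.

Measured so far:
- compound 1, `CC(C)(C)c1cc(NC(=O)Nc2cc(C(F)(F)F)cc(C(F)(F)F)c2)n(-c2ccccc2)n1`, in an assay on isolated protein for inhibition of Ephrin type-A receptor 2 (Homo sapiens), read by thermal shift assay, tested at 10 uM; on this read-out higher numbers stand for stronger stabilisation of the target against heat and lower numbers for weaker stabilisation of the target: 0.8 degrees C
- compound 2, `Cc1cc(C)cc(NC(=O)Nc2cc(C(C)(C)C)nn2-c2ccccc2)c1`, in this assay: 0.7 degrees C
- compound 3, `Cc1ccc(S(=O)(=O)NC(=O)Nc2cc(C(C)(C)C)nn2-c2ccccc2)cc1`, in this assay: 0.2 degrees C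

Compound 2 stands second highest of the three numbers, but its gap to compound 1 and its gap to compound 3 both lie within the scatter of this assay, so the three values cannot be ranked against each other. All three shifts are small.

Compound 4, `Cc1ccc(NC(=O)Nc2cc(C(C)(C)C)nn2-c2ccccc2)cc1`, has not yet been measured. It differs from compound 2 in one place: 4-methylphenyl in place of 3,5-dimethylphenyl on an amide-type nitrogen. Within the data shown here, no step between measured compounds is available for this change. Given that compound 2 with 0.7 degrees C sits among three values that do not separate, the expectation for compound 4 is no step beyond the scatter, in either direction; the expected step of a number 0.10 degrees C lower from compound 2 to compound 4 (within the scatter) is small. The estimate for compound 4 in this assay is 0.6 degrees C, with an expected range from -0.3 degrees C to 1.5 degrees C.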

Compound 4, shift of the target's melting temperature: 1.7 degrees C
Compound 4: the middle estimate sits 1.1 degrees C below what was measured, outside the stated range (above it).
By their numbers in this assay, from the lowest: compounds 3, 2, 1 and 4 (each within the scatter of the next, the first and the last beyond it).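

Among these compounds, this is the first step that can be read at this position: in this assay, 4-methylphenyl in place of 3,5-dimethylphenyl on an amide-type nitrogen gives a number 1.0 degrees C higher from compound 2 to compound 4 (within the scatter). Among the compounds shown here, the step is large beside the small values of the earlier compounds, yet it still lies within the scatter, so compound 2 and compound 4 do not separate and the change cannot be called a gain. The position accepts this swap with no loss of stabilisation, and nothing measured gives an explanation for this step.

For the compounds shown here, the single step cannot tell whether the number of methyl groups or their placement on the ring matters more. Also open, going by these compounds, is whether an unsubstituted phenyl, or a phenyl carrying an amine or a carboxylic acid, would give a step beyond the scatter on this nitrogen.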